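Swapping a Pentyl Chain for a Phenyl Ring

The compounds below may be only part of what the source reports. "The series", "measured", "known", "first", "only" and "open" are said of these compounds alone.

Compound 3 `CCCCCOc1ccc(-c2c(C)[nH]c(=O)n2C2CCCCC2)cc1` sits second highest among the three numbers in a functional assay on brain (Rattus norvegicus, strain Wistar) for inhibition; a higher number here means a weaker inhibitor, a lower number a stronger inhibitor: compound 3 gives 9100 nM, close to compound 1 `CCCCc1ccc(-c2c(C)[nH]c(=O)n2C)cc1`, for which compound 1 gives 10700 nM, and separated by a step from compound 2 `CCCCCOc1ccc(-c2c(C)[nH]c(=O)n2C)cc1`, where compound 2 gives 4500 nM. The two measured steps are a 2.4-fold lower number from compound 1 to compound 2 (0.38 log units; beyond the scatter) and a 2.0-fold higher number from compound 2 to compound 3 (0.31 log units; beyond the scatter). Compound 4 `Cc1[nH]c(=O)n(C2CCCCC2)c1-c1ccc(Oc2ccccc2)cc1` differs from compound 3 by phenyl in place of pentyl on an oxygen on an aromatic ring. Among the measured compounds shown here, neither measured step concerns this kind of change: one alters the chain on the aromatic carbon, the other the group on the aromatic nitrogen, and no measured pair exchanges a chain for a ring on the oxygen. Both measured steps were modest, so a modest change in this assay or none beyond the scatter is expected here, with no direction to prefer. For compound 4 the estimated step is a 1.1-fold lower number from compound 3 to compound 4 (0.06 log units; within the scatter). Compound 4 is therefore expected to give 8000 nM, within a range from 2500 nM to 25000 nM.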

Compound 4, half-maximal inhibitory concentration: 7900 nM
Compound 4: the middle estimate sits 1.0-fold (0.01 log units) above what was measured; the range from low to high includes it.
By their numbers in this assay, from the lowest: compounds 2, 4, 3 and 1 (each within the scatter of the next, the first and the last beyond it).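

On the oxygen on an aromatic ring, a phenyl ring can take the place of the pentyl chain with no change that stands out from the scatter: this assay gives a 1.2-fold lower number from compound 3 to compound 4 (0.06 log units; within the scatter) here. Among the compounds shown here, the earlier compounds showed only a pentyl chain on this oxygen, so this pair is the first sign that, with cyclohexyl on the aromatic nitrogen, an aromatic ring and an open chain read alike at this position. Nothing at hand explains why the two groups read alike.

Whether phenyl and pentyl also read alike with methyl on the aromatic nitrogen, as in compound 2, stays open, as the swap is shown only with cyclohexyl. Also open, from the compounds shown here alone, is what a benzyl group, or a phenyl ring carrying an amine or a carboxylic acid, would do on this oxygen.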